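Cyano in place of nitro: a cytotoxicity question

The source may hold more compounds than are shown below. What is called first, only, known or untested is meant among the compounds shown, and "the series" means these compounds.

In an ADME assay on THP-1 cells (Homo sapiens) for cytotoxicity, read by trypan blue exclusion, with a stated time of 24 h (on this read-out lower numbers stand for stronger inhibition and higher numbers for weaker inhibition), compound 1 `N#C[Se]c1ccc(N)cc1` gives > 50000 nM, which is a limit of the assay and not a number. Compound 2 `N#C[Se]Cc1cccc([N+](=O)[O-])c1` gives 9320 nM, and compound 3 `CSc1ccc(C[Se]C#N)cc1` gives 17000 nM. Among the compounds with values here, these two values lie within the scatter of each other, so compound 2 stands level with the only other compound that has a number. Compound 4 `N#C[Se]Cc1cccc(C#N)c1` differs from compound 2 at one place, with cyano in place of nitro on an aromatic carbon. Within the data shown here, no measured pair isolates this change, so no shift beyond the scatter is expected in this assay. The expected change is a 1.3-fold higher number from compound 2 to compound 4 (0.11 log units; within the scatter), a small one in the direction of weaker inhibition. For compound 4 the estimated value is 12000 nM, with an expected range of 5000 nM to 30000 nM.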

Compound 4, half-maximal inhibitory concentration: 7600 nM
Beside the measured number, compound 4's estimate is 1.6-fold (0.20 log units) above it, within the range that was stated.
By their numbers in this assay, from the lowest: compounds 4, 2 and 3 (each within the scatter of the next, the first and the last beyond it). At a limit, above all of these: compound 1.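

In this assay, within the data shown here, cyano in place of nitro on an aromatic carbon gives a 1.2-fold lower number from compound 2 to compound 4 (0.09 log units; within the scatter), the first step in this set that isolates a single change. At this place on the ring, the two groups stand level, so the value of compound 2 does not depend on nitro in particular.

As far as these compounds go, whether a carboxylic acid or a trifluoromethyl group on the same aromatic carbon would also stay level with compound 2 remains open. Nothing shown here explains why nitro and cyano stand level.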